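This account rests on a few compounds, and the source may have more. Where it says the series, first, only, none or still open, it means among the compounds named here.

Among the measured compounds shown here, compound 1, with the structure `Cc1cc(Nc2cc(-c3ccccc3)[nH]n2)n2nc(SCCc3ccccc3)nc2n1`, is the one compound of the three measured that returns a number in a functional assay on PC-9 cells (Homo sapiens) for inhibition, read by MTT assay, with a stated time of 72 h; a higher number here means a weaker inhibitor, a lower number a stronger inhibitor: compound 1 gives 4930 nM. Compound 2, with the structure `Cc1cc(Nc2cc(-c3ccccc3)[nH]n2)n2nc(SCC3CCCCC3)nc2n1`, reaches only a limit of this assay, where compound 2 gives > 50000 nM. Compound 3, with the structure `C#CCSc1nc2nc(C)cc(Nc3cc(-c4ccccc4)[nH]n3)n2n1`, likewise sits at a limit, where compound 3 gives > 50000 nM. Both measured steps away from compound 1 move in the same direction: an at least 10-fold higher number from compound 1 to compound 2 (1.00 log units; beyond the scatter), and an at least 10-fold higher number from compound 1 to compound 3 (1.00 log units; beyond the scatter). Between the two limits the step that the two limits leave unreadable from compound 2 to compound 3.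

Compound 4, with the structure `Cc1ccc(CSc2nc3nc(C)cc(Nc4cc(-c5ccccc5)[nH]n4)n3n2)cc1`, differs from compound 1 in a single place: 4-methylphenyl in place of benzyl on a saturated chain carbon bound to a sulfur. This change keeps one six-membered aromatic ring of carbon only on the saturated chain carbon bound to the sulfur, whereas both measured steps, to the cyclohexyl of compound 2 and to the ethynyl of compound 3, removed that ring and ended at the limit (the limit of > 50000 nM in this assay, at which 2 of the 3 values shown sit). For the measured compounds named here, no measured step exchanges benzyl for 4-methylphenyl, so the size of the step is not read from any pair here. With the ring retained, compound 4 is expected to move only modestly, a 1.6-fold higher number from compound 1 to compound 4 (0.21 log units; within the scatter), toward a weaker result. Compound 4 is therefore estimated at 8000 nM, within a range from 3000 nM to 30000 nM.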

Compound 4, half-maximal inhibitory concentration: 7310 nM
For compound 4 the middle estimate is 1.1-fold (0.04 log units) above the measured one; the range from low to high includes it.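

Exchanging benzyl for 4-methylphenyl on a saturated chain carbon bound to a sulfur rearranges the same atoms and gives a 1.5-fold higher number from compound 1 to compound 4 (0.17 log units; within the scatter), so this rearrangement leaves no readable change in this assay. Set against the groups without a six-membered aromatic ring of carbon only, 4-methylphenyl gives an at least 6.8-fold lower number from compound 3 to compound 4 (0.83 log units; beyond the scatter) and an at least 6.8-fold lower number from compound 2 to compound 4 (0.83 log units; beyond the scatter), so a second compound carrying such a ring at this place returns a number, and none of the four compounds shown goes against that pattern. Both of these steps start from a limit of the assay and not from a number, so their full size stays unknown: the limit of > 50000 nM in this assay, at which 2 of the 4 values shown sit.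

The compounds shown leave open whether a pyridine ring, an amine or a carboxylic acid on the ring, or a longer chain on the sulfur would still return a number in this assay. They also do not show whether any group at this place can give a number clearly lower than those of compound 1 and compound 4.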